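From Chloro to Fluoro: One Atom Changed

A few compounds are considered here, and "the series" means these few. Any claim that something is new, unique, unknown or untested is made for them only; others in the source may bear on it.

Of the compounds shown here, two have been tested so far in a functional assay (aorta) for inhibition, with Rattus norvegicus as the target; a higher number here means a weaker inhibitor, a lower number a stronger inhibitor. Compound 1 (`CC1(C)Oc2ccc(C#N)cc2[C@@H](/N=C(\NC#N)Nc2ccccc2)[C@@H]1O`) was tested repeatedly and gave 1400 nM; 4200 nM; 1300 nM (3 entries), a spread that warns against reading much into small gaps. Compound 2 (`CC1(C)Oc2ccc(C#N)cc2[C@@H](/N=C(\NC#N)Nc2ccc(Cl)cc2)[C@@H]1O`), which carries a 4-chlorophenyl group, gave 1800 nM. Going by the values given here, that is the only single number available, as compound 1 has several entries instead. Compound 3 (`CC1(C)Oc2ccc(C#N)cc2[C@@H](/N=C(\NC#N)Nc2ccc(F)cc2)[C@@H]1O`) has not yet been measured. It has fluoro in place of chloro on an aromatic carbon, para to a large group: fluoro in place of chloro on an aromatic carbon. Among the compounds with values here, no measured pair yet shows what such a swap does in this test. The expected step of no change at the digits printed from compound 2 to compound 3 (within the scatter) is none beyond the usual scatter, with no direction favoured. For compound 3 the estimated value is 1800 nM, with an expected range from 700 nM to 4500 nM.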

Compound 3, half-maximal inhibitory concentration: 1400 nM
For compound 3 the middle estimate is 1.3-fold (0.11 log units) above the measured one; the measured number falls inside the stated range.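

In this assay, putting fluoro in place of chloro on this aromatic carbon, para to a large group, gives a 1.3-fold lower number from compound 2 to compound 3 (0.11 log units; within the scatter). Going by these compounds alone, this is the first measured pair to test such a swap, and in this assay chloro and fluoro at this position cannot be told apart. A step of this size is also smaller than the spread seen when a single compound is tested repeatedly: the several entries of compound 1 in this assay, 1400 nM; 4200 nM; 1300 nM (3 entries)

This one pair leaves open whether a methoxy group, an amine or a carboxylic acid at the same place would move the number beyond the scatter. It also cannot tell whether the swap from chloro to fluoro would read the same way on a different core or in a different test.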